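The compounds below may be only part of what the source reports. "The series", "measured", "known", "first", "only" and "open" are said of these compounds alone.

Compound 1 `O=C1[C@@H](NS(=O)(=O)c2ccc(-c3ccon3)s2)CCN1Cc1cc2c[nH]ccc-2n1` was tested in an assay on isolated protein for inhibition of coagulation factor X (Oryctolagus cuniculus), tested at 1 uM (on this read-out higher numbers stand for more inhibition at the one concentration tested (going by the name of the read-out) and lower numbers for less inhibition), and gives 17%. Among the three measured compounds it stands second highest. Its nearest neighbour is compound 3 `O=C1[C@@H](NS(=O)(=O)c2ccc(-c3ccccn3)s2)CCN1Cc1cc2c[nH]ccc-2n1`, which in this assay gives 11%; the step of a number 6 percentage points lower from compound 1 to compound 3 (within the scatter) came with pyridin-2-yl in place of 1,2-oxazol-3-yl on an aromatic carbon. Furthest away is compound 2 `O=C1[C@@H](NS(=O)(=O)c2ccc(-c3ccon3)s2)CCN1Cc1cc2cc[nH]cc-2n1`, which gives 49%; the step of a number 32 percentage points higher from compound 1 to compound 2 (beyond the scatter) came with the exchange of the group on the saturated chain carbon bound to the amide-type nitrogen.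

Compound 4 `O=C1[C@@H](NS(=O)(=O)c2cc3c(Cl)nccc3s2)CCN1Cc1cc2c[nH]ccc-2n1` is not yet measured. It differs from compound 1 by a group of 10 heavy atoms (7 carbon, 1 nitrogen, 1 sulfur, 1 chlorine; one five-membered aromatic ring with 1 hetero atom, one six-membered aromatic ring with 1 hetero atom) in place of a group of 10 heavy atoms (7 carbon, 1 nitrogen, 1 oxygen, 1 sulfur; one five-membered aromatic ring with 1 hetero atom, one five-membered aromatic ring with 2 hetero atoms), on a sulfonyl sulfur. Among the compounds with values here, only the step from compound 1 to compound 3 touches this part of the molecule, and it was within the scatter, so no firm direction can be read from it; the step from compound 1 to compound 2 changed a different region. The replacement in compound 4 is larger than that in compound 3, so a wide range is kept. Compound 4 is therefore expected to show a number 3 percentage points higher from compound 1 to compound 4 (within the scatter), with an estimated value of 20%, between 5% and 45%.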

Compound 4, a percentage reported as inhibition, at one concentration (the size of the read-out at that concentration, not a potency): 35%
The estimate for compound 4 lay 15 percentage points below the measured number, and the stated range covers the measured number.
By their numbers in this assay, from the lowest: compounds 3 and 1 (each within the scatter of the next); then compound 4; then compound 2.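

In this assay the group on the sulfonyl sulfur can clearly shift the result, as a number 18 percentage points higher from compound 1 to compound 4 (beyond the scatter) shows, whereas the pyridin-2-yl exchange in compound 3 stayed within the scatter. The entering group has the same heavy-atom count as 5-(1,2-oxazol-3-yl)thiophen-2-yl, so this step came without any change in that count, although the atoms, the ring sizes and the hydrogen-bond acceptor count all differ. No measurement available here accounts for the step.

The compounds shown do not separate the contribution of the chlorine from that of the two-ring group carrying it, which a version with hydrogen or methyl in its place would address. Going by these compounds, it also remains open whether this sulfonyl group and the group that distinguishes compound 2 would add up in one molecule.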